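Permeability notes on the anilinopyrrolidine acid series

The source may hold more compounds than are shown below. What is called first, only, known or untested is meant among the compounds shown, and "the series" means these compounds.

Measured so far:
- compound 1 `C[C@@H](N[C@H]1CCN(c2ccc(C(=O)NCC(=O)O)cc2)C1)c1cccc2ccccc12`: "not determined" (no result reported)
- compound 2 `C[C@@H](N[C@H]1CCN(c2ccc(S(=O)(=O)NC(=O)CC(=O)O)cc2)C1)c1cccc2ccccc12`: "not determined" (no result reported)
- compound 3 `C[C@@H](N[C@H]1CCN(c2ccc(C(=O)NCCS(=O)(=O)O)cc2)C1)c1cccc2ccccc12`: 4 nm/s

In an ADME assay on MDCK cells (Canis lupus familiaris) for inhibition, read by LC-MS, with a stated time of 60 min, tested at 3 uM, in the presence of a further agent that is not named here (a higher number here means that the compound crosses the layer faster, a lower number that the compound crosses the layer more slowly), only compound 3 has a number; compound 2 has none, and compound 1 is a second entry without one. Compound 2 therefore has no position on the numbers shown. Compound 4 `C[C@@H](N[C@H]1CCN(c2ccc(C(=O)N[C@H](CC(=O)O)C(=O)O)cc2)C1)c1cccc2ccccc12` is the next entry for this assay. The change from compound 2 to compound 4 is (1,2-dicarboxyethyl)carbamoyl in place of ((carboxymethyl)carbonyl)sulfamoyl on an aromatic carbon. For the measured compounds named here, with no number for compound 2, no step in this assay can be framed, in either direction. Because compound 3 gives 4 nm/s in this assay, compound 4 is expected near 3 nm/s, with a range of 1 nm/s to 10 nm/s.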

Compound 4, apparent permeability: 9 nm/s
Compound 4: middle estimate off by 3.0-fold (0.48 log units), on the low side, and the stated range covers the measured number.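

With 1,2-dicarboxyethyl in place of 2-sulfoethyl on the amide-type nitrogen, this assay gives a 2.3-fold higher number from compound 3 to compound 4 (0.35 log units; beyond the scatter), so this position responds to the change by more than the usual scatter. The change from compound 2 to compound 4 cannot be read, as compound 2 has no number. Nothing measured on these compounds accounts for the step.

Still open, from the compounds shown here alone, is how this assay would read with a primary amide or a tetrazole at the end of the chain on that nitrogen, or with a longer chain bearing a single carboxylic acid.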